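The source may report more compounds than this note shows. Statements on the series, on what has been measured and on what is new or still open speak of the compounds shown alone.

Measured in a functional assay on KB cells (Homo sapiens), read by MTT assay; on this read-out lower numbers stand for stronger inhibition and higher numbers for weaker inhibition:
- Compound 1 `CCC#C[C@@]1(O)[C@@H](CO)O[C@@H](n2ccc(N)nc2=O)[C@@H]1O`: 108000 nM
- Compound 2 `C#CC[C@@]1(O)[C@@H](CO)O[C@@H](n2ccc(N)nc2=O)[C@@H]1O`: > 350000 nM (a limit)
- Compound 3 `C#C[C@H]1[C@@H](O)[C@H](n2ccc(=O)[nH]c2=O)O[C@@H]1CO`: > 350000 nM (a limit)

Compound 3 gives no true number in this assay. Its entry of > 350000 nM is a limit. It shares this position with compound 2, so the set offers (the limit of > 350000 nM in this assay, at which 2 of the 3 values shown sit). Only compound 1 has a true number.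

Compound 4 `C#C[C@@H]1[C@@H](O)[C@H](n2ccc(=O)[nH]c2=O)O[C@@H]1CO` is the next to be measured. Its relation to compound 3 is simple: the two compounds have the same atoms and bonds and differ only in configuration as drawn: 1 of 4 stereo elements differ; a stereocentre at a saturated ring carbon is drawn S in compound 3 and R in compound 4. Nothing is added or removed, and a stereocentre at a saturated ring carbon is simply drawn the other way.

Going by the values given here, the one measured step is an at least 3.2-fold higher number from compound 1 to compound 2 (0.51 log units; beyond the scatter). It replaces but-1-yn-1-yl with propargyl, a change of group and not of configuration, so it bears on the new pair only loosely. It does show that a modest change can move the read-out beyond the scatter. Among the compounds with values here, no measured pair tests a change of configuration alone. A lower number for compound 4 remains possible, but the more likely outcome is no step beyond the scatter, quite possibly with another limit.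

The expected change is a number no higher from compound 3 to compound 4 (the limit leaves the size open). Compound 4 is estimated at 350000 nM, with an expected range from 120000 nM to 700000 nM.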

Compound 4, half-maximal inhibitory concentration: > 350000 nM
Compound 4 ended at the assay's limit; the forecaster's own chance of this, stated with the estimate: 75%; the middle value sits exactly at the limit.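

Compound 3 and compound 4 both end at a limit in this assay and not at a true number, and no step can be read between them: the limit of > 350000 nM in this assay, at which 3 of the 4 values shown sit.

The compounds shown leave open whether drawing this one stereocentre at a saturated ring carbon the other way changes the read-out at all: the fact that compounds 3 and 4 differ only in the configuration as drawn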